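Methyl for Cyano on the Sulfonamide Ring

The source may hold more compounds than are shown below. What is called first, only, known or untested is meant among the compounds shown, and "the series" means these compounds.

Measured compounds:
`CC(C(=O)NCc1ccc(C(C)(C)C)cc1)c1ccc(NS(C)(=O)=O)c(Br)c1` (compound 1): 7.4 nM
`CC(C(=O)NCc1ccc(C(C)(C)C)cc1)c1ccc(NS(C)(=O)=O)c(C#N)c1` (compound 2): 344 nM

Compound 1 `CC(C(=O)NCc1ccc(C(C)(C)C)cc1)c1ccc(NS(C)(=O)=O)c(Br)c1` and compound 2 `CC(C(=O)NCc1ccc(C(C)(C)C)cc1)c1ccc(NS(C)(=O)=O)c(C#N)c1` were tested in an assay on CHO cells for displacement of a labelled ligand from transient receptor potential cation channel subfamily V member 1 (Rattus norvegicus), read by scintillation counting, with a stated time of 60 min; on this read-out higher numbers stand for weaker inhibition and lower numbers for stronger inhibition. In this assay compound 1 gives 7.4 nM, while compound 2 gives 344 nM, the highest of the two numbers; its nearest neighbour is compound 1, and the step of a 46-fold higher number from compound 1 to compound 2 (1.67 log units; beyond the scatter) is large.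

Compound 3 `Cc1cc(C(C)C(=O)NCc2ccc(C(C)(C)C)cc2)ccc1NS(C)(=O)=O` has not been measured. It differs from compound 2 by methyl in place of cyano on an aromatic carbon. For the measured compounds named here, the only measured step at this position, a 46-fold higher number from compound 1 to compound 2 (1.67 log units; beyond the scatter), ran from bromo to cyano, so the data cover a cyano group leaving but not a methyl group entering; no step shows methyl at this place. Since replacing bromo with cyano raised the number far beyond the scatter, removing the cyano is expected to bring the number back part of the way toward compound 1, though not necessarily all of it.

Compound 3 is therefore expected to show 30 nM, within a range of 8 nM to 120 nM, corresponding to an estimated step of an 11-fold lower number from compound 2 to compound 3 (1.06 log units; beyond the scatter).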

Compound 3, inhibition constant: 32.8 nM
For compound 3 the middle estimate is 1.1-fold (0.04 log units) below the measured one; measured number inside the range.
By their numbers in this assay, from the lowest: compound 1; then compound 3; then compound 2.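

Putting a methyl group on this aromatic carbon, ortho to the methanesulfonamido group, gives a 10-fold lower number from compound 2 to compound 3 (1.02 log units; beyond the scatter) in this assay and thus shows that the loss seen with cyano is not common to every replacement of bromo at this place. Methyl still does not match bromo, with a 4.4-fold higher number from compound 1 to compound 3 (0.65 log units; beyond the scatter) separating the two, so the three groups fall into a clear order at this single position, with bromo giving the strongest inhibition, methyl an intermediate level and cyano the weakest. Nothing given here accounts for this order.

On these data alone, it remains open whether chloro, methoxy, an amine or plain hydrogen at this carbon would come closer to bromo or stay nearer to methyl. As far as these compounds go, it is equally open whether the same order would hold if the methanesulfonamido group or the tert-butyl end of the shared core were changed.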